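The source may report more compounds than this note shows. Statements on the series, on what has been measured and on what is new or still open speak of the compounds shown alone.

Working notes on the series. Compound 1 `CCOC(=O)CC1C(C(=O)OCC)=C(N)Oc2ccc(-c3cc(OC)cc(OC)c3)cc21`, compound 2 `CCOC(=O)C1=C(N)Oc2ccc(-c3cc(OC)cc(OC)c3)cc2C1CC(=O)c1ccccc1` and compound 3 `C#CCOC(=O)CC1C(C(=O)OCC#C)=C(N)Oc2ccc(-c3cccc(N)c3)cc21` have been measured in a functional assay on HL-60 cells (Homo sapiens) for inhibition, with a stated time of 48 h; on this read-out higher numbers stand for weaker inhibition and lower numbers for stronger inhibition. In this assay compound 1 gives 5400 nM, compound 2 gives 109000 nM and compound 3 gives 1730 nM. Compound 3 therefore stands lowest of the three numbers; the nearest is compound 1 and the furthest is compound 2. Within the data shown here, the only single-point step measured so far, a 20-fold higher number from compound 1 to compound 2 (1.31 log units; beyond the scatter), concerns the carbonyl substituent and not the aryl group.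

The next compound, compound 4 `C#CCOC(=O)CC1C(C(=O)OCC#C)=C(N)Oc2ccc(-c3cc(OC)cc(OC)c3)cc21`, differs from compound 3 as follows: 3,5-dimethoxyphenyl in place of 3-aminophenyl on an aromatic carbon. Among the measured compounds shown here, no measured step bears on an exchange of the aryl group. Compound 1 also carries the 3,5-dimethoxyphenyl group, but it differs from compound 3 in the esters as well, so its value beside that of compound 3 is only indirect; the two values are not far apart. The step from compound 3 to compound 4 in this assay is thus expected to be modest, a 1.7-fold higher number from compound 3 to compound 4 (0.24 log units; within the scatter), in no firmly predicted direction. Compound 4 is estimated at 3000 nM, within a range of 800 nM to 12000 nM.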

Compound 4, half-maximal inhibitory concentration: 1160 nM
Estimate against measurement, compound 4: 2.6-fold (0.41 log units) above; the range from low to high includes it.
By their numbers in this assay, from the lowest: compounds 4 and 3 (each within the scatter of the next); then compound 1; then compound 2.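

Among these compounds, the first measured exchange of the aryl group, 3,5-dimethoxyphenyl in place of 3-aminophenyl on an aromatic carbon of the shared core, gives a 1.5-fold lower number from compound 3 to compound 4 (0.17 log units; within the scatter) and so leaves compound 3 and compound 4 indistinguishable in this assay. With the esters unchanged, this pair shows that the amine on the aryl ring is not needed to retain the reading, and that the two methoxy groups serve equally well at this position. Nothing available explains why the two aryl groups read alike.

Still open, going by these compounds, is whether a plain phenyl, a 3-hydroxyphenyl or a 3-carboxyphenyl group would read the same at this position. Also open, on these data alone, is whether this equivalence of the two aryl groups would hold with ethyl esters in place of the present ones.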